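Triazole-phthalimide series: benzoyl removal on the sulfur-bound chain carbon

A few compounds are considered here, and "the series" means these few. Any claim that something is new, unique, unknown or untested is made for them only; others in the source may bear on it.

Compound 1 `Cc1nnc(SCC(=O)c2ccccc2)n1N1C(=O)c2ccccc2C1=O` is the reference point of the series. In a functional assay on PC-3M cells (Homo sapiens) for cytotoxicity, read by MTT assay, with a stated time of 48 h (a lower number here means a stronger inhibitor, a higher number a weaker inhibitor), compound 1 gives > 200000 nM, which is a limit of the assay. Compound 2 `CSc1nnc(C)n1N1C(=O)c2ccccc2C1=O` differs from compound 1 by hydrogen in place of benzoyl on a saturated chain carbon bound to a sulfur. In this assay compound 2 gives > 200000 nM, also a limit of the assay. The step that the two limits leave unreadable from compound 1 to compound 2 cannot be sized because of the limit of > 200000 nM in this assay, at which 3 of the 3 values shown sit. Compound 3 `CCCc1nnc(SCC(=O)c2ccccc2)n1N1C(=O)c2ccccc2C1=O` differs from compound 1 in its core by ethyl in place of hydrogen on a saturated chain carbon bound to an aromatic carbon. In this assay compound 3 gives > 200000 nM, again a limit of the assay. The step that the two limits leave unreadable from compound 1 to compound 3 is therefore equally unreadable. Compound 4 `CCCc1nnc(SC)n1N1C(=O)c2ccccc2C1=O` is not yet measured; it differs from compound 3 by hydrogen in place of benzoyl on a saturated chain carbon bound to a sulfur, the same change that separates compound 2 from compound 1, and the place is given in identical words, on a saturated chain carbon bound to a sulfur. Because the step that the two limits leave unreadable from compound 1 to compound 2 could not be read and every measured member sits at the limit, the step that the limit leaves unreadable from compound 3 to compound 4 is expected, with no basis for a gain. Compound 4 is estimated at 300000 nM, between 100000 nM and 1000000 nM, and is most likely to be reported as a limit once more.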

Compound 4, half-maximal inhibitory concentration: > 200000 nM
Compound 4: no number, only a limit (the forecaster's own chance of this, stated with the estimate: 85%); the middle value is on the limit's open side.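

Neither compound 3 to compound 4 nor compound 2 to compound 4 gives a readable step, because each value is a limit and not a number: the limit of > 200000 nM in this assay, at which 4 of the 4 values shown sit. The compounds shown leave open whether exchanging benzoyl for hydrogen or hydrogen for ethyl changes activity in this assay at any concentration beyond that limit.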